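Hydroxy on the anilino ring of a lactone-bearing diterpenoid

A few compounds are considered here, and "the series" means these few. Any claim that something is new, unique, unknown or untested is made for them only; others in the source may bear on it.

Measured compounds:
compound 1, `C=C1[C@@H](OC(C)=O)C[C@@H]2[C@](C)(CO[Si](C)(C)C(C)(C)C)[C@H](OC(C)=O)CC[C@@]2(C)[C@@H]1C[C@@H](Nc1ccccc1)C1=CCOC1=O` — 4840 nM
compound 2, `C=C1[C@@H](C/C=C2/C(=O)OC[C@H]2OC(C)=O)[C@]2(C)CC[C@@H](OC(C)=O)[C@@](C)(CO[Si](C)(C)C(C)(C)C)[C@H]2C[C@@H]1O` — 6960 nM

Of the compounds shown here, two sharing the same core have been tested in a functional assay on MCF7 cells (Homo sapiens) for cytotoxicity, read by sulforhodamine B assay; on this read-out lower numbers stand for stronger inhibition and higher numbers for weaker inhibition. Compound 1 gives 4840 nM and compound 2 gives 6960 nM. The two numbers lie within the usual scatter of each other, so on what has been measured compound 1 and compound 2 cannot be told apart, and no ordering between them can be claimed.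

The step under consideration leads from compound 1 to compound 3, `C=C1[C@@H](OC(C)=O)C[C@@H]2[C@](C)(CO[Si](C)(C)C(C)(C)C)[C@H](OC(C)=O)CC[C@@]2(C)[C@@H]1C[C@@H](Nc1ccc(O)cc1)C1=CCOC1=O`. The change is confined to the anilino side chain: hydroxy in place of hydrogen on an aromatic carbon. Read one bond further out, the anilino group becomes a (4-hydroxyphenyl)amino group.

Among the measured compounds shown here, no pair of measured compounds differing in one place is available, so the size of this step has no precedent in these data. The change adds a single oxygen to a peripheral aromatic ring while the core and the lactone remain untouched; a step of at most the usual scatter is expected, in no particular direction. Compound 3 is therefore estimated at 4500 nM, with a range from 1500 nM to 13000 nM, which corresponds to an expected step of a 1.1-fold lower number from compound 1 to compound 3 (0.03 log units; within the scatter).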

Compound 3, half-maximal inhibitory concentration: 5220 nM
Beside the measured number, compound 3's estimate is 1.2-fold (0.06 log units) below it, within the range that was stated.
By their numbers in this assay, from the lowest: compounds 1, 3 and 2 (each within the scatter of the next).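

In this assay, among the compounds shown here, the first step available between compounds that differ in one place is a 1.1-fold higher number from compound 1 to compound 3 (0.03 log units; within the scatter) and so lies within the scatter. Hydroxy in place of hydrogen on this aromatic carbon, para to a large group, therefore brings in a hydrogen-bond donor and acceptor on the anilino ring without any difference that this assay can separate from repeat variation. This single step shows that the position tolerates this one substitution, but nothing available explains the outcome, and no supporting measurement bears on it.

The compounds shown leave open whether the flat result is particular to hydroxy or holds for this place more generally, since a methoxy group, an amine, a carboxylic acid or a fluorine atom on the same aromatic carbon might give a step beyond the scatter. They also leave open whether the aromatic ring matters at all, which replacing the anilino group with a simple butylamino chain would address.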